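The compounds below may be only part of what the source reports. "The series", "measured", "known", "first", "only" and "open" are said of these compounds alone.

Compound 1 `COc1cc(/C=C2\CNC/C(=C\c3cc(OC)c(OC)c(OC)c3)C2=O)cc(OC)c1OC` – 4000 nM
Compound 2 `CCCN1C/C(=C\c2ccc(OC)c(OC)c2)C(=O)/C(=C/c2ccc(OC)c(OC)c2)C1` – 11200 nM

Going by the values given here, in a functional assay on NCI-H1975 cells (Homo sapiens) for cytotoxicity, read by MTT assay, with a stated time of 72 h (a lower number here means a stronger inhibitor, a higher number a weaker inhibitor), compound 1 gives 4000 nM and holds the lower of the two numbers so far. Compound 2 is the nearest at 11200 nM and sits beyond the usual scatter of repeat measurements, so compound 1 is the stronger inhibitor of this pair. Among the compounds with values here, these two compounds differ in more than one place, so no measured pair shows the effect of a single change.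

The next compound is compound 3 `CCN1C/C(=C\c2cc(OC)c(OC)c(OC)c2)C(=O)/C(=C/c2cc(OC)c(OC)c(OC)c2)C1` and it differs from compound 1 in one place. The change is ethyl in place of hydrogen on an amine nitrogen in a ring and amounts to ethyl in place of hydrogen on an amine nitrogen in a ring.

Compound 2 also carries a chain on that nitrogen and gives 11200 nM but has other differences too, so it is only a loose guide. The expected change is a 1.4-fold higher number from compound 1 to compound 3 (0.14 log units; within the scatter) and points toward a slightly weaker number, with nothing expected beyond the scatter. For compound 3 the estimated value is 5500 nM with an expected range from 1800 nM to 16000 nM in this measurement.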

Compound 3, half-maximal inhibitory concentration: 6500 nM
The estimate for compound 3 lay 1.2-fold (0.07 log units) below the measured number, within the range that was stated.
By their numbers in this assay, from the lowest: compounds 1, 3 and 2 (each within the scatter of the next, the first and the last beyond it).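

Going by these compounds alone, compound 1 and compound 3 form the first pair that isolates a single change, so the nitrogen in the six-membered ring can now be judged without the other differences that blurred the earlier comparison. In this assay putting ethyl in place of hydrogen on this amine nitrogen gives a 1.6-fold higher number from compound 1 to compound 3 (0.21 log units; within the scatter) and so makes no difference that can be told apart from repeat-measurement noise, which means that this nitrogen can carry a small chain of 2 carbon atoms without a clear loss or gain in this cell assay. No measurement at hand explains this result or shows what the ethyl group does in the cells.

A single pair cannot show how far this holds: a longer chain such as butyl, a benzyl group or a chain ending in an amine or a carboxylic acid on the same nitrogen could behave quite differently. Going by these compounds, it also remains open whether ethyl would have the same small effect with aromatic groups other than those of compound 1 on the shared core.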